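The compounds below may be only part of what the source reports. "The series", "measured", "known", "first", "only" and "open" are said of these compounds alone.

Measured compounds in a functional assay on HEK293 cells for agonist activity at Free fatty acid receptor 1 (Homo sapiens), read by fluorescence and calcium flux; a lower number here means that less compound is needed, a higher number that more compound is needed for the effect:
compound 1 `CC#CC(CC(=O)O)c1ccc(OCc2ccc(C(=O)N3CCN(c4ccccc4)CC3)s2)cc1` gives 72 nM
compound 2 `CC#CC(CC(=O)O)c1ccc(OCc2ccc(C(=O)N3CCN(C4CCCCC4)CC3)s2)cc1` gives 820 nM
compound 3 `CC#CC(CC(=O)O)c1ccc(OCc2ccc(C(=O)N3CCN(c4ccncc4)CC3)s2)cc1` gives > 5000 nM, which is a limit of the assay and not a number.

Compound 3 thus stands at the weak end of the three, known only as a bound, namely (the limit of > 5000 nM in this assay, at which 1 of the 3 values shown sits). The step of an at least 69-fold higher number from compound 1 to compound 3 (1.84 log units; beyond the scatter) is large; the step of an at least 6.0-fold higher number from compound 2 to compound 3 (0.78 log units; beyond the scatter) is also beyond the scatter; and an 11-fold higher number from compound 1 to compound 2 (1.06 log units; beyond the scatter) shows that even cyclohexyl in place of phenyl on that ring nitrogen costs much in this assay.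

Compound 4 `CC#CC(CC(=O)O)c1ccc(OCc2ccc(C(=O)N3CCN(c4ccccn4)CC3)s2)cc1` is the next point: pyridin-2-yl in place of pyridin-4-yl on an amine nitrogen in a ring. Going by the values given here, none of the measured steps moves the nitrogen within the same aromatic ring on this position; they only compare phenyl, cyclohexyl and pyridin-4-yl there. They show that the group on that ring nitrogen matters strongly in this assay and that pyridin-4-yl is the weakest tested, but whether pyridin-2-yl recovers part of what phenyl gives cannot be read from them. The expected step is an at least 1.6-fold lower number from compound 3 to compound 4 (0.22 log units; that floor lies within the scatter), a move toward a lower number but of uncertain size, with a fair chance of another limit. Compound 4 is estimated at 3000 nM, within 700 nM to 15000 nM.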

Compound 4, half-maximal effective concentration: 138 nM
Compound 4: middle estimate off by 22-fold (1.34 log units), on the high side, and the stated range ends above it.
By their numbers in this assay, from the lowest: compounds 1 and 4 (each within the scatter of the next); then compound 2. At a limit, above all of these: compound 3.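

Moving the nitrogen within the same aromatic ring, with the same atoms joined differently, is by itself a large change at this position in this assay, and it gives an at least 36-fold lower number from compound 3 to compound 4 (1.55 log units; beyond the scatter); a nitrogen in this ring therefore does not by itself bring the loss seen with pyridin-4-yl. The aromatic pyridin-2-yl also stands apart from the saturated cyclohexyl, with a 5.9-fold lower number from compound 2 to compound 4 (0.77 log units; beyond the scatter), while a 1.9-fold higher number from compound 1 to compound 4 (0.28 log units; within the scatter) does not separate pyridin-2-yl from phenyl, so that the earlier contrast between phenyl and pyridin-4-yl now reads as a matter of where the nitrogen sits and not of whether the ring holds one. The size of the first step is only a floor, since compound 3 stands as a limit of the assay and not a number: the limit of > 5000 nM in this assay, at which 1 of the 4 values shown sits.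

The compounds shown leave open how pyridin-3-yl behaves on the same amine nitrogen, and so whether the cost of the ring nitrogen rises gradually or appears only with pyridin-4-yl. They also leave open whether a methyl group or a fluorine on the pyridin-2-yl ring would move the number in either direction.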